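Halogen swap on the aryl arm of a cyanopyridine series

A few compounds are considered here, and "the series" means these few. Any claim that something is new, unique, unknown or untested is made for them only; others in the source may bear on it.

Compound 1 `CCOc1nc(-c2cc3ccccc3o2)cc(-c2cccc3ccccc23)c1C#N`: 344000 nM
Compound 2 `CCOc1nc(-c2cc3ccccc3o2)cc(-c2ccc3ccccc3c2)c1C#N`: 423000 nM
Compound 3 `CCOc1nc(-c2cc3ccccc3o2)cc(-c2ccc(Br)cc2)c1C#N`: 227000 nM

Of the compounds shown here, three sharing one core have been tested in a functional assay on aorta (strain Wistar) for inhibition, with Thoracic aorta (Rattus norvegicus) as the target; on this read-out higher numbers stand for weaker inhibition and lower numbers for stronger inhibition. In this assay compound 1 gives 344000 nM, compound 2 gives 423000 nM, and compound 3 gives 227000 nM. The number for compound 3 is the smallest of the three, yet the steps that separate it from its neighbours, a 1.5-fold lower number from compound 1 to compound 3 (0.18 log units; within the scatter) and a 1.9-fold lower number from compound 2 to compound 3 (0.27 log units; within the scatter), both fall within the scatter, as does a 1.2-fold higher number from compound 1 to compound 2 (0.09 log units; within the scatter). On the numbers shown, then, the three aryl arms cannot be told apart.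

Compound 4 `CCOc1nc(-c2cc3ccccc3o2)cc(-c2ccc(F)cc2)c1C#N` is the next member, not yet measured. It differs from compound 3 by fluoro in place of bromo on an aromatic carbon. For the measured compounds named here, none of the measured steps touches a halogen; each exchanges one whole aryl arm for another, and each stays within the scatter. Going by the values given here, there is thus no step here that bears directly on this change, and no indication that any variation of the aryl arm moves this assay beyond the scatter. The expectation for compound 4 is therefore a step of a 1.2-fold higher number from compound 3 to compound 4 (0.09 log units; within the scatter), no larger than the scatter. Compound 4 is estimated to give 280000 nM in this assay, within a range from 130000 nM to 600000 nM.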

Compound 4, half-maximal inhibitory concentration: 396000 nM
The estimate for compound 4 lay 1.4-fold (0.15 log units) below the measured number, within the range that was stated.
By their numbers in this assay, from the lowest: compounds 3, 1, 4 and 2 (each within the scatter of the next).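

In this assay, for the compounds shown here, this is the first change at the halogen itself, on the aromatic carbon para to a large group, and fluoro in place of bromo gives a step that stays within the scatter (a 1.7-fold higher number from compound 3 to compound 4 (0.24 log units; within the scatter)). The 4-fluorophenyl arm also cannot be told apart from either naphthyl arm, as the steps against the naphthalen-2-yl compound (a 1.1-fold lower number from compound 2 to compound 4 (0.03 log units; within the scatter)) and the naphthalen-1-yl compound (a 1.2-fold higher number from compound 1 to compound 4 (0.06 log units; within the scatter)) show, so all four arms now lie within the scatter of one another wherever a step is printed. No measurement offered here speaks to why the halogen exchange leaves the number within the scatter.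

The compounds shown leave open whether any other group at this place, such as an amine or a carboxylic acid in place of the halogen, would move the number beyond the scatter. They also leave open whether changing the ethoxy group or the nitrile of the shared core, both of which stay the same in all four compounds, would do so.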